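The compounds below may be only part of what the source reports. "The series", "measured", "known", "first", "only" and "open" are said of these compounds alone.

Measured so far in a functional assay on U-251 cells (Homo sapiens) for antiproliferative activity, read by MTT assay, with a stated time of 72 h; a lower number here means a stronger inhibitor, a higher number a weaker inhibitor:
Compound 1 `O=C(Nc1ccc(Cl)c(-c2nnc3c(Cl)cccn23)c1)c1ccc(C(F)(F)F)cc1Cl` gives > 100000 nM, which is a limit of the assay and not a number.
Compound 2 `O=C(Nc1ccc(Cl)c(-c2nnc3c(Cl)cccn23)c1)c1ccccn1` gives 79000 nM.
Compound 3 `O=C(Nc1ccc(Cl)c(-c2nnc3c(Cl)cccn23)c1)c1ccc(C(F)(F)F)cc1F` gives > 100000 nM, again only a limit of the assay.

Going by the values given here, compound 2 therefore stands as the only compound with a real number; the other two values sit at the limit of > 100000 nM in this assay, at which 2 of the 3 values shown sit. Among the compounds with values here, the one measured step, a step that the two limits leave unreadable from compound 1 to compound 3, yields no readable size, so nothing measured here bears on the exchange that follows.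

Compound 4 `CS(=O)(=O)c1ccc(C(=O)Nc2ccc(Cl)c(-c3nnc4c(Cl)cccn34)c2)cc1` differs from compound 2 by 4-(methylsulfonyl)phenyl in place of pyridin-2-yl on a carbonyl carbon. Within the data shown here, with no comparable step in hand, compound 4 is expected to stay close to compound 2 in this assay, an expected step of a 1.1-fold higher number from compound 2 to compound 4 (0.06 log units; within the scatter). For compound 4 the estimate is 90000 nM, expected to fall between 30000 nM and 300000 nM.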

Compound 4, half-maximal inhibitory concentration: > 100000 nM
Compound 4: no number, only a limit; the forecaster's own chance of this, stated with the estimate: 45%; at least 1.1-fold (0.04 log units) between middle value and limit.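

Here, 4-(methylsulfonyl)phenyl in place of pyridin-2-yl on the carbonyl carbon gives an at least 1.2-fold higher number from compound 2 to compound 4 (0.10 log units; that floor lies within the scatter), the first step at this position that can be read at all. As far as these compounds go, compound 4 gives only a limit of the assay, > 100000 nM, so the true size of the step stays unknown and the readable part does not exceed the usual scatter. In this assay, compound 4 joins the compounds without a real number: the limit of > 100000 nM in this assay, at which 3 of the 4 values shown sit.

Still open, from the compounds shown here alone, is how a ring carrying an amine or a carboxylic acid would read on this carbonyl carbon. Also open, going by these compounds, is whether any group there brings the number clearly under that of compound 2.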